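Swapping methanesulfonamido for sulfamoylmethyl on a shared core

The source may hold more compounds than are shown below. What is called first, only, known or untested is meant among the compounds shown, and "the series" means these compounds.

Measured in a functional assay on KB cells (nasopharynx, Homo sapiens) for antiproliferative activity; on this read-out higher numbers stand for weaker inhibition and lower numbers for stronger inhibition:
- compound 1 `NC(=O)c1ccc(S(=O)(=O)Nc2cccc3c(Cl)c[nH]c23)cc1`: 21 ug/mL
- compound 2 `CS(=O)(=O)Nc1ccc(S(=O)(=O)Nc2cccc3c(Cl)c[nH]c23)cc1`: 12 ug/mL

Compound 2 has a single measured neighbour, compound 1, and their two values lie within the scatter of each other. Compound 3 `NS(=O)(=O)Cc1ccc(S(=O)(=O)Nc2cccc3c(Cl)c[nH]c23)cc1` holds the same atoms as compound 2, joined differently: sulfamoylmethyl in place of methanesulfonamido on an aromatic carbon. In short, sulfamoylmethyl stands in place of methanesulfonamido on an aromatic carbon. Among the measured compounds shown here, one measured step bears on this, also a swap of groups on an aromatic carbon: a 1.8-fold lower number from compound 1 to compound 2 (0.24 log units; within the scatter). Going by that step, no change beyond the scatter is expected in this assay, and the expected result is a 1.2-fold higher number from compound 2 to compound 3 (0.07 log units; within the scatter). The estimate for compound 3 is 14 ug/mL, with an expected range of 6 ug/mL to 32 ug/mL.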

Compound 3, half-maximal inhibitory concentration: 13 ug/mL
Compound 3: the middle estimate sits 1.1-fold (0.03 log units) above what was measured; the measured number falls inside the stated range.
By their numbers in this assay, from the lowest: compounds 2, 3 and 1 (each within the scatter of the next).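

In this assay, joining the same atoms as sulfamoylmethyl instead of methanesulfonamido on this aromatic carbon gives a 1.1-fold higher number from compound 2 to compound 3 (0.03 log units; within the scatter), and replacing carbamoyl with sulfamoylmethyl gives a 1.6-fold lower number from compound 1 to compound 3 (0.21 log units; within the scatter). Carbamoyl, methanesulfonamido and sulfamoylmethyl, each para to a large group, thus all lie within the scatter of one another, so this rearrangement of atoms leaves no resolved difference. No supporting measurement bears on this result. From the compounds shown here alone, whether an amine, a carboxylic acid or a longer chain at this aromatic carbon would give a number beyond the scatter remains open.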